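Trifluoromethyl for Trifluoromethoxy in a Two-Number Series

The source may hold more compounds than are shown below. What is called first, only, known or untested is meant among the compounds shown, and "the series" means these compounds.

Among the measured compounds shown here, only two numbers are available so far. In a functional assay on NALM-6 cells (Homo sapiens) for cytotoxicity, read by luminescence and CellTiter-Glo, with a stated time of 3 days (a higher number here means a weaker inhibitor, a lower number a stronger inhibitor), compound 1 `O=C(Nc1ccc(C(F)(F)F)cc1)c1cc(Cl)ccc1O` gives 1210 nM and compound 2 `O=C(Nc1ccc(OC(F)(F)F)c(Cl)c1)c1cc(Cl)ccc1O` gives 1050 nM in the same test. Compound 2 therefore stands level with compound 1, since the gap between these two values lies within the usual scatter of repeated measurements.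

The next compound is compound 3 `O=C(Nc1ccc(C(F)(F)F)c(Cl)c1)c1cc(Cl)ccc1O` which carries trifluoromethyl in place of trifluoromethoxy on an aromatic carbon ortho to a chloro group. For the measured compounds named here, no measured pair shows this exchange, so the data point in neither direction. With no evidence for a shift, the estimated change a 1.0-fold higher number from compound 2 to compound 3 (0.02 log units; within the scatter) is expected to stay within the scatter. In this assay the estimated value for compound 3 is 1100 nM with an expected range of 500 nM to 2400 nM for most repeat measurements.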

Compound 3, half-maximal inhibitory concentration: 1220 nM
The estimate for compound 3 lay 1.1-fold (0.04 log units) below the measured number; the range from low to high includes it.
By their numbers in this assay, from the lowest: compounds 2, 1 and 3 (each within the scatter of the next).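

In this assay, placing trifluoromethyl in place of trifluoromethoxy on an aromatic carbon ortho to a chloro group gives a 1.2-fold higher number from compound 2 to compound 3 (0.07 log units; within the scatter), so this exchange now has a direct reading and the two compounds stand level. Chloro in place of hydrogen on the same ring, with trifluoromethyl kept, gives a 1.0-fold higher number from compound 1 to compound 3 (0.00 log units; within the scatter), so that pair stands level as well. Nothing available here explains why these compounds stand level.

Going by these compounds, each exchange rests on a single pair, so it remains open whether a quite different group at this position, such as an amine, a carboxylic acid or a longer chain, would give a number beyond the scatter. Also open is how chloro behaves alongside trifluoromethoxy, since the compounds shown carry that group only together with chloro.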